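The compounds below may be only part of what the source reports. "The series", "measured", "known", "first", "only" and "open" are said of these compounds alone.

Compound 2 `CCOC(=O)CCCCCOc1cccc(CN(C(=O)c2ccc(-c3cccc(F)c3)cc2)C(C)C)c1` is tested in an ADME assay on BJ cells (Homo sapiens) for cytotoxicity, read by CellTiter-Glo and resazurin assay, with a stated time of 72 h (on this read-out higher numbers stand for an effect only at larger amounts of compound and lower numbers for an effect already at smaller amounts), where compound 2 gives > 26000 nM, a limit of the assay rather than a number. Compound 1 `CCOC(=O)CCCCCOc1cccc(CN(C(=O)c2ccc(-c3cccc(OC(C)C)c3)cc2)C(C)C)c1` gives > 26000 nM in this assay, again only a limit. Going by the values given here, the single recorded step, a step that the two limits leave unreadable from compound 1 to compound 2, is therefore unreadable, as the limit of > 26000 nM in this assay, at which 2 of the 2 values shown sit, shows. Compound 3 `CCOC(=O)CCCCCOc1cccc(CN(C(=O)c2ccc(-c3cccc([N+](=O)[O-])c3)cc2)C(C)C)c1` differs from compound 2 by nitro in place of fluoro on an aromatic carbon. Among the compounds with values here, no measured step bears on this change, so nothing beyond the scatter is expected, and the step that the limit leaves unreadable from compound 2 to compound 3 is offered as an estimate only. Compound 3 is expected to give 30000 nM, within a range of 10000 nM to 90000 nM.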

Compound 3, half-maximal effective concentration: < 1.3 nM
Compound 3 gave a limit, no number (the forecaster's own chance of this, stated with the estimate: 75%); at least 23000-fold (4.36 log units) between middle value and limit.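

In this assay, the group on this aromatic carbon turns out to matter, which compounds 1 and 2, both at the same limit, could not show. Nitro in place of fluoro gives an at least 20000-fold lower number from compound 2 to compound 3 (4.30 log units; beyond the scatter), and nitro in place of isopropoxy gives an at least 20000-fold lower number from compound 1 to compound 3 (4.30 log units; beyond the scatter). The value of compound 3 is itself a limit of the assay and not a number: the limit of < 1.3 nM in this assay, at which 1 of the 3 values shown sits.

The compounds shown leave open how far compound 3 lies past its limit. They also leave open whether an amine or a nitrile on the same carbon would read like nitro or like fluoro.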